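From Amide to Urea: Estimating Compound 4

This account rests on a few compounds, and the source may have more. Where it says the series, first, only, none or still open, it means among the compounds named here.

In an ADME assay on microsomes from liver (Homo sapiens) for metabolic stability, with a stated time of 10 min (a lower number here means that less of the compound is left, a higher number that more of the compound is left), compound 1 `CCCCCNc1nc(Nc2ccc([N+](=O)[O-])cc2)nc(OCC(F)(F)F)n1` gives 74%; compound 2 `CC(C)C(=O)NCCS(=O)(=O)NC(=O)c1ccc(Nc2nc(NC3(c4ccc(Cl)cc4)CC3)nc(OCC(F)(F)F)n2)cc1` gives 86%; compound 3 `O=C(NS(=O)(=O)c1ccccc1)c1ccc(Nc2nc(NC3(c4ccc(Cl)cc4)CC3)nc(OCC(F)(F)F)n2)cc1` gives 100%.

Compound 2 stands second highest of the three in this assay: compound 1 sits lower by a gap beyond the scatter, and the step of a number 14 percentage points higher from compound 2 to compound 3 (beyond the scatter) runs upward. Compound 4 `CC(C)NC(=O)NCCS(=O)(=O)NC(=O)c1ccc(Nc2nc(NC3(c4ccc(Cl)cc4)CC3)nc(OCC(F)(F)F)n2)cc1` differs from compound 2 by isopropylamino in place of isopropyl on a carbonyl carbon. Going by the values given here, the one measured step, from compound 2 to compound 3, alters the group on the sulfonyl sulfur, not the carbonyl carbon, so no measured step bears directly on this change, and compound 1 lacks the side chain entirely. With nothing bearing on it, the expected change is none beyond the scatter. Compound 4 is therefore estimated at 88%, between 74% and 100%. That estimate corresponds to an expected step of a number 2 percentage points higher from compound 2 to compound 4 (within the scatter).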

Compound 4, percent of the compound remaining: 100%
Compound 4: middle estimate off by 12 percentage points, on the low side; the range from low to high includes it.
By their numbers in this assay, from the lowest: compound 1; then compound 2; then compounds 3 and 4 (each within the scatter of the next).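

In this assay, going by these compounds alone, the carbonyl carbon of the side chain proves sensitive to change: isopropylamino in place of isopropyl gives a number 14 percentage points higher from compound 2 to compound 4 (beyond the scatter) and thereby supplies the first measured step at this place. The side chain need not fall short of phenyl on the sulfonyl sulfur, as 2-((isopropylcarbamoyl)amino)ethyl in place of phenyl gives no change at the digits printed from compound 3 to compound 4 (within the scatter) and so matches it. Nothing at hand explains the gain at the carbonyl carbon. As far as these compounds go, it remains open whether a methylamino group, a dimethylamino group or an ethoxy group on that carbon would give the same result.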